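This account rests on a few compounds, and the source may have more. Where it says the series, first, only, none or still open, it means among the compounds named here.

Measured in a physicochemical assay for solubility, measured as kinetic solubility (on this read-out higher numbers stand for higher solubility and lower numbers for lower solubility), each value a limit of the assay:
- compound 1 `Oc1c(-c2nc(C(O)c3ccccc3)n[nH]2)ncc2cccnc12` gives > 250000 nM
- compound 2 `Cc1n[nH]c(-c2ncc3cccnc3c2O)n1` gives > 250000 nM
- compound 3 `O=C1CCCN1Cc1n[nH]c(-c2ncc3cccnc3c2O)n1` gives > 250000 nM

Compound 2 has no number to stand on, since its > 250000 nM is a limit. The same holds across the series, with the limit of > 250000 nM in this assay, at which 3 of the 3 values shown sit.

Compound 4 `CNc1ccnc2c(O)c(-c3nc(C)n[nH]3)ncc12` differs from compound 2 as follows: methylamino in place of hydrogen on an aromatic carbon. Methylamino takes the place of hydrogen on an aromatic carbon, opposite the ring nitrogen.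

Three measured steps exist: a step that the two limits leave unreadable from compound 1 to compound 2, a step that the two limits leave unreadable from compound 1 to compound 3 and a step that the two limits leave unreadable from compound 2 to compound 3. All of them concern a different place from this change, and none has a readable size. They therefore give no size or direction to carry over, and no step beyond the scatter is expected in this assay.

The expected step is a number no higher from compound 2 to compound 4 (the limit leaves the size open). For compound 4 the estimate is 250000 nM, with an expected range of 90000 nM to 500000 nM.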

Compound 4, solubility: > 250000 nM
Compound 4: no number, only a limit (the forecaster's own chance of this, stated with the estimate: 70%); the middle value sits exactly at the limit.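

In this assay compound 4 gives > 250000 nM, which is a limit, so the pair compound 2 and compound 4 yields no readable step: the limit of > 250000 nM in this assay, at which 4 of the 4 values shown sit.

The compounds shown leave open whether methylamino in place of hydrogen on an aromatic carbon changes the read-out of this assay at all, and how the four compounds rank.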